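Removing the fluoro from the benzyl amide of compound 1

This account rests on a few compounds, and the source may have more. Where it says the series, first, only, none or still open, it means among the compounds named here.

Compound 1 `C=CC1=C(C(=O)NCc2ccccc2F)C(c2ccc(F)cc2)OC1` has been run in a functional assay on HeLa cells (Homo sapiens) for cytotoxicity, read by MTT assay, with a stated time of 24 h; on this read-out higher numbers stand for weaker inhibition and lower numbers for stronger inhibition. In this assay compound 1 gives only a limit, > 100000 nM, and no number. Compound 2 `C=CC1=C(C(=O)NCc2ccc(Cl)cc2)C(c2ccc(OC)cc2)OC1` likewise reaches only a limit in this assay, > 100000 nM. Compound 1 therefore stands where every value seen so far stands, namely at the limit of > 100000 nM in this assay, at which 2 of the 2 values shown sit, with no measured number in the series to rank it against.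

Compound 3 `C=CC1=C(C(=O)NCc2ccccc2)C(c2ccc(F)cc2)OC1` is not yet measured. It differs from compound 1 in one place: hydrogen in place of fluoro on an aromatic carbon, so the 2-fluorobenzyl becomes benzyl. Going by the values given here, no step between two measured compounds is known in this assay, so the size of this change cannot be read from the series; both values seen sit at the limit, and removing a single fluoro from the benzyl is expected to shift the read-out by no more than the scatter, if at all. The expected step is a step that the limit leaves unreadable from compound 1 to compound 3, essentially none beyond the scatter. For compound 3 the expected value in this assay is 120000 nM, within 50000 nM to 300000 nM, and most likely it is again reported only as a limit.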

Compound 3, half-maximal inhibitory concentration: > 100000 nM
Compound 3: no number, only a limit; the forecaster's own chance of this, stated with the estimate: 85%; the middle value is on the limit's open side.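

In this assay compound 3 gives > 100000 nM, a limit and not a number. Compound 1 also gives only a limit, so no step can be read from compound 1 to compound 3 for 2-fluorobenzyl to benzyl. All values shown share one position: the limit of > 100000 nM in this assay, at which 3 of the 3 values shown sit. The compounds shown leave open what number, if any, this series would reach in this assay.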